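A few compounds are considered here, and "the series" means these few. Any claim that something is new, unique, unknown or untested is made for them only; others in the source may bear on it.

Measured in a functional assay on MIA PaCa-2 cells (Homo sapiens) for inhibition, read by MTT assay; a higher number here means a weaker inhibitor, a lower number a stronger inhibitor:
compound 1 `O=C(Nc1ccc[n+]([O-])c1)c1cc2cnc(Nc3ccc(N4CCNCC4)cn3)nc2n1C1CCCC1`: 125000 nM
compound 2 `COc1ccccc1NC(=O)c1cc2cnc(Nc3ccc(N4CCNCC4)cn3)nc2n1C1CCCC1`: 1830 nM
compound 3 `O=C(Nc1ccccc1Cl)c1cc2cnc(Nc3ccc(N4CCNCC4)cn3)nc2n1C1CCCC1`: 2170 nM

Compound 3 sits among the lower numbers of this short set, with two steps fixing its place: a 1.2-fold higher number from compound 2 to compound 3 (0.07 log units; within the scatter), and a 58-fold lower number from compound 1 to compound 3 (1.76 log units; beyond the scatter). Compound 4 `O=C(Nc1ccccc1C(F)(F)F)c1cc2cnc(Nc3ccc(N4CCNCC4)cn3)nc2n1C1CCCC1` differs from it by trifluoromethyl in place of chloro on an aromatic carbon. For the measured compounds named here, the nearest precedent is the chloro and methoxy exchange at that same carbon, which stayed within the scatter. The large steps of a 68-fold lower number from compound 1 to compound 2 (1.83 log units; beyond the scatter) and a 58-fold lower number from compound 1 to compound 3 (1.76 log units; beyond the scatter) replace the whole ring on the amide-type nitrogen, so they bear only weakly. Going by the values given here, no measured compound carries trifluoromethyl. In this assay the expected change is small, a 1.0-fold higher number from compound 3 to compound 4 (0.01 log units; within the scatter), with no direction favoured. For compound 4 the estimate is 2200 nM, with an expected range of 900 nM to 5500 nM.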

Compound 4, half-maximal inhibitory concentration: 3160 nM
Beside the measured number, compound 4's estimate is 1.4-fold (0.16 log units) below it, within the range that was stated.
By their numbers in this assay, from the lowest: compounds 2, 3 and 4 (each within the scatter of the next); then compound 1.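

In this assay, trifluoromethyl on this aromatic carbon, ortho to a large group, leaves the number level with both chloro (a 1.5-fold higher number from compound 3 to compound 4 (0.16 log units; within the scatter)) and methoxy (a 1.7-fold higher number from compound 2 to compound 4 (0.24 log units; within the scatter)), so a third group at this place cannot be told apart from the first two. Replacing the whole ring remains the large change (a 40-fold lower number from compound 1 to compound 4 (1.60 log units; beyond the scatter)), and compound 1 stays apart from compounds 2, 3 and 4. No measurement bears on why these steps take these sizes.

Still open, on these data alone, is whether an amine or a carboxylic acid at this same carbon would also leave the number level.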